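Swapping the aryl amine for a benzyl amine

The compounds below may be only part of what the source reports. "The series", "measured", "known", "first", "only" and "open" are said of these compounds alone.

Compound 1 `Nc1ccccc1NC(=O)/C=C/c1ccc(Cn2cnc3c(Nc4cccc(OC(F)(F)F)c4)nc(Cl)nc32)cc1` stands lowest of the three compounds measured in a functional assay on NCI-H460 cells (Homo sapiens) for antiproliferative activity, read by CCK-8 assay, with a stated time of 72 h, tested at 2 uM (a higher number here means a stronger effect of the compound at the concentration tested, a lower number a weaker effect), where compound 1 gives 2.1%. For the measured compounds named here, its nearest neighbour in the numbers, compound 3 `Nc1ccccc1NC(=O)c1ccc(Cn2cnc3c(Nc4cccc(OC(F)(F)F)c4)nc(Cl)nc32)cc1`, gives 47.7%, and the step of a number 45.6 percentage points higher from compound 1 to compound 3 (beyond the scatter) is the only single-point change recorded among the measured compounds. Compound 2 `CC(C)n1cnc2c(NCc3ccc(C(=O)Nc4ccccc4N)cc3)nc(Cl)nc21` gives 54.2%; it differs from compound 3 in more than one place, so those two values can only be set side by side.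

Compound 4 `Nc1ccccc1NC(=O)/C=C/c1ccc(Cn2cnc3c(NCc4ccccc4)nc(Cl)nc32)cc1` is reached from compound 1 by benzyl in place of 3-(trifluoromethoxy)phenyl on a nitrogen on an aromatic ring. Going by the values given here, no measured step touches this nitrogen: the one recorded step changed the linker instead, and compound 2 and compound 3 both carry the direct carbamoyl linker rather than the ethenyl one. What compound 4 keeps is the ethenyl linker, with which compound 1 gave 2.1% in this assay. With nothing showing that a change at the nitrogen alone moves the number, the step expected here is a number 7.9 percentage points higher from compound 1 to compound 4 (within the scatter), small and likely within the scatter, with a slight lean upward. The estimate for compound 4 is 10%, expected to fall between 0% and 35%.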

Compound 4, a percentage reported as inhibition, at one concentration (the size of the read-out at that concentration, not a potency): 4.62%
The estimate for compound 4 lay 5.4 percentage points above the measured number; the measured number falls inside the stated range.
By their numbers in this assay, from the lowest: compounds 1 and 4 (each within the scatter of the next); then compounds 3 and 2 (each within the scatter of the next).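

For the compounds shown here, exchanging 3-(trifluoromethoxy)phenyl for benzyl on the nitrogen gives a number 2.5 percentage points higher from compound 1 to compound 4 (within the scatter) in this assay, and this is the first direct reading of a change at this position. Although the group there goes from 11 heavy atoms to 7 and loses its oxygen and fluorine atoms, the values of the two compounds cannot be told apart, so on the ethenyl linker this exchange shows no measurable effect at the single concentration tested. Nothing available explains this result, and no cause can be assigned to it.

Both compounds sit near the bottom of the percentage scale, so the result leaves open whether the same exchange would also make no difference on the direct carbamoyl linker of compound 3, where the read-out has more room to fall. On these data alone, it also remains open how this nitrogen would respond to a group of a different kind, such as a morpholine or a short chain ending in a carboxylic acid, and how any such group would read on either linker.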